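Chalcone-thiazole anilines: methyl on the anilino ring

The compounds below may be only part of what the source reports. "The series", "measured", "known", "first", "only" and "open" are said of these compounds alone.

Measured so far:
compound 1 `Cc1ccccc1Nc1nc(C)c(C(=O)/C=C/c2ccccc2)s1` — > 25000 nM
compound 2 `Cc1nc(Nc2ccccc2)sc1C(=O)/C=C/c1ccccc1` — > 25000 nM
compound 3 `COc1cc(/C=C/C(=O)c2sc(Nc3ccccc3)nc2C)cc(OC)c1OC` — > 25000 nM

In a functional assay on PC-3 cells (Homo sapiens) for cytotoxicity, read by MTT assay (a higher number here means a weaker inhibitor, a lower number a stronger inhibitor), compound 2 gives only a limit, > 25000 nM. Compound 1 likewise gives only a limit, > 25000 nM. The change between them, (methyl in place of hydrogen on an aromatic carbon), therefore gives a step that is not readable: a step that the two limits leave unreadable from compound 2 to compound 1. Compound 3 also gives only a limit, > 25000 nM; the difference between its core and that of compound 2 is not broken down here. All three values sit at the same point, (the limit of > 25000 nM in this assay, at which 3 of the 3 values shown sit).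

Compound 4 `COc1cc(/C=C/C(=O)c2sc(Nc3ccc(C)cc3)nc2C)cc(OC)c1OC` is not yet measured. It carries the same kind of change as compound 1, (methyl in place of hydrogen on an aromatic carbon), but here the methyl sits para to a large group rather than ortho to it. Since compound 3 reaches only the limit > 25000 nM and the earlier step of this kind was unreadable, compound 4 is expected to reach about 30000 nM in this assay, an expected step that the limit leaves unreadable from compound 3 to compound 4, most likely again reported as a limit.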

Compound 4, half-maximal inhibitory concentration: > 25000 nM
Compound 4 gave a limit, no number; the forecaster's own chance of this, stated with the estimate: 80%; the middle value does not contradict the limit.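

Compound 3 and compound 4 each give only a limit, so no step can be read between them: the limit of > 25000 nM in this assay, at which 4 of the 4 values shown sit. Whether methyl in place of hydrogen changes anything in this series stays open: none of the compounds shown gives a number.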